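This account rests on a few compounds, and the source may have more. Where it says the series, first, only, none or still open, it means among the compounds named here.

Measured compounds:
compound 1 `Cc1ccc(C(=O)Nc2cc(-c3ccccc3)nn2-c2ccccc2)cc1` — 64 nM in a functional assay on cells for positive allosteric modulation of metabotropic glutamate receptor 5 (Rattus norvegicus), read by calcium flux; on this read-out higher numbers stand for an effect only at larger amounts of compound and lower numbers for an effect already at smaller amounts
compound 2 `O=C(Nc1cc(-c2ccccc2)nn1-c1ccccc1)c1ccc(OC(F)(F)F)cc1` — compound 2 gives 18 nM
compound 3 `O=C(Nc1cc(-c2ccccc2)nn1-c1ccccc1)c1ccc(C(F)(F)F)cc1` — compound 3 gives 38 nM

Within this trio compound 3 holds the second highest number. Its nearest neighbour is compound 1, with a 1.7-fold lower number from compound 1 to compound 3 (0.23 log units; within the scatter) separating them, so these two cannot be ordered. Compound 2 sits lower, with a 2.1-fold higher number from compound 2 to compound 3 (0.32 log units; beyond the scatter) lying beyond the scatter.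

The next compound, compound 4 `Cc1ccc(C(=O)Nc2cc(-c3ccccc3)nn2-c2ccccc2)cn1`, alters the aryl group on the carbonyl carbon: 6-methylpyridin-3-yl in place of 4-(trifluoromethyl)phenyl on a carbonyl carbon. Among the compounds with values here, all measured steps so far concern only the substituent on that ring — a 3.6-fold lower number from compound 1 to compound 2 (0.55 log units; beyond the scatter), a 1.7-fold lower number from compound 1 to compound 3 (0.23 log units; within the scatter) and a 2.1-fold higher number from compound 2 to compound 3 (0.32 log units; beyond the scatter) — and none exchanges a ring carbon for a ring nitrogen, so the step to compound 4 lacks a direct precedent. What the data do show is that a methyl-bearing ring and a trifluoromethyl-bearing ring differ only within the scatter, the nearest comparison being compound 1 at 64 nM. On that basis a small shift, if any, is expected for compound 4, with the wider uncertainty of an untested ring change: the step of a 2.4-fold higher number from compound 3 to compound 4 (0.37 log units; beyond the scatter) is the estimate. Compound 4 is therefore expected at about 90 nM, in the range 30 nM to 300 nM.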

Compound 4, half-maximal effective concentration: 280 nM
The estimate for compound 4 lay 3.1-fold (0.49 log units) below the measured number; the measured number falls inside the stated range.
By their numbers in this assay, from the lowest: compound 2; then compounds 3 and 1 (each within the scatter of the next); then compound 4.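

In this assay, the aryl group on the carbonyl carbon responds to a change in the ring itself and not only to a change in its substituent. Within the data shown here, with the methyl retained, a ring nitrogen in place of a ring carbon gives a 4.4-fold higher number from compound 1 to compound 4 (0.64 log units; beyond the scatter), the only step here that isolates this exchange and one that lies beyond the scatter. The step of a 7.4-fold higher number from compound 3 to compound 4 (0.87 log units; beyond the scatter) is also beyond the scatter, but it exchanges the ring atom and the substituent together and so cannot be assigned to either one; no measurement available here explains why the ring nitrogen raises the number.

Still open, going by these compounds, is whether the same ring exchange raises the number equally when the ring carries trifluoromethyl or trifluoromethoxy, the substituents of compound 3 and compound 2, which would show whether the substituent and ring effects add independently. Also open, on these data alone, is how this pyridine ring behaves with an amine, a carboxylic acid or a longer alkyl chain in place of the methyl, and how changes elsewhere on the shared core would interact with it.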